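The compounds below may be only part of what the source reports. "The series", "measured", "known", "first", "only" and "open" are said of these compounds alone.

Notes on the series. In an assay on HeLa cells for displacement of a labelled ligand from adenosine receptor A3 (Homo sapiens), read by scintillation counting, with a stated time of 180 min, tested at 10 uM (a lower number here means less inhibition, a higher number more inhibition at the concentration tested (going by the name of the read-out)), compound 1 `COCCNC(=O)c1cc2cccc(OC)c2oc1=O` gives 0%. Compound 2 `COc1cccc2cc(C(=O)NCC(O)CO)c(=O)oc12` gives 1% in this assay, and compound 3 `COc1cccc2cc(C(=O)N[C@@H](CO)C(=O)O)c(=O)oc12` gives 3%. Compound 2 stands second highest of the three numbers; the nearest step to it is a number 1 percentage points higher from compound 1 to compound 2 (within the scatter) and the furthest a number 2 percentage points higher from compound 2 to compound 3 (within the scatter), while the remaining step is a number 3 percentage points higher from compound 1 to compound 3 (within the scatter). All three steps lie within the scatter, and all three compounds sit close to zero inhibition.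

Compound 4 `O=C(NCC(O)CO)c1cc2cccc(O)c2oc1=O` is not yet measured. Its difference from compound 2 is hydrogen in place of methyl on an oxygen on an aromatic ring. Among the measured compounds shown here, none of the measured steps touches this place: each of them changes the group on the amide-type nitrogen while the methoxy on the aromatic ring is kept throughout. So no measured step bears directly on the change from compound 2 to compound 4. What the series does show is that three different amide substituents all leave the read-out near zero, so there is no measurable inhibition in the shared core of compound 2 that a change on an oxygen on an aromatic ring could readily lower, and nothing in the data points to a rise. The expected step of a number 1 percentage points higher from compound 2 to compound 4 (within the scatter) is therefore none beyond the scatter. Compound 4 is estimated at 2%, with a range of -8% to 14%.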

Compound 4, a percentage reported as inhibition, at one concentration (the size of the read-out at that concentration, not a potency): 22%
Compound 4: the middle estimate sits 20 percentage points below what was measured; the whole stated range lies below it.
By their numbers in this assay, from the lowest: compounds 1, 2 and 3 (each within the scatter of the next); then compound 4.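

Methoxy to hydroxy on the aromatic ring is the only change shown so far that moves the read-out: in this assay it gives a number 21 percentage points higher from compound 2 to compound 4 (beyond the scatter) while the 2,3-dihydroxypropyl group on the amide-type nitrogen stays in place. The amide substituents of compound 1, compound 2 and compound 3 all lie within the scatter of one another, so among the compounds shown, the oxygen on the aromatic ring is the one place where a change in inhibition at the tested concentration can be read. No measurement at hand accounts for the effect of replacing this methyl with hydrogen.

The compounds shown leave open whether the same change gives a similar step with another amide substituent, such as the 2-methoxyethyl of compound 1 or the 1-carboxy-2-hydroxyethyl of compound 3. They also leave open how the read-out responds to an ethyl or a longer alkyl chain on that oxygen, or to an amine in place of the hydroxy group.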